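This account rests on a few compounds, and the source may have more. Where it says the series, first, only, none or still open, it means among the compounds named here.

The compounds measured so far in a physicochemical assay for solubility, in phosphate buffer, with a stated time of 2 h, at pH 7.4 (on this read-out lower numbers stand for lower solubility and higher numbers for higher solubility), are these:
Compound 1 `Clc1ccc(Nc2nc(-c3ccccn3)cs2)nc1` gives the limit < 10000 nM
Compound 2 `COc1ccnc(-c2csc(Nc3ccc(Cl)cn3)n2)c1` gives the limit < 10000 nM
Compound 3 `COc1cccc(-c2csc(Nc3ccc(Cl)cn3)n2)n1` gives the limit < 10000 nM

Compound 1 stands at < 10000 nM in this assay, which is a limit and not a number. The two other compounds are known only as limits too. The whole record comes down to the limit of < 10000 nM in this assay, at which 3 of the 3 values shown sit, and offers nothing finer.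

Compound 4 `CCOc1ccc(-c2csc(Nc3ccc(Cl)cn3)n2)nc1` has not yet been measured. It differs from compound 1 by ethoxy in place of hydrogen on an aromatic carbon. Two measured changes come closest, each with methoxy in place of hydrogen on an aromatic carbon. Among the compounds with values here, the first is a step that the two limits leave unreadable from compound 1 to compound 2, and the second is a step that the two limits leave unreadable from compound 1 to compound 3 as well. Neither gives a size or a direction to carry over to ethoxy.

No step beyond the usual scatter is therefore expected in this assay, and the estimated change is a step that the limit leaves unreadable from compound 1 to compound 4 with no direction to be read from it. Another limit is the most likely report. Should a number appear, compound 4 is expected at 5000 nM (estimated range 1500 nM to 10000 nM).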

Compound 4, solubility: < 10000 nM
Compound 4 gave a limit, no number; the forecaster's own chance of this, stated with the estimate: 85%; the middle value is on the limit's open side.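

In this assay compound 4 gives < 10000 nM, which is a limit and not a number, so no new step can be read between compound 1 and compound 4. The compounds shown leave open where any of them actually stands, and whether methoxy or ethoxy in place of hydrogen changes the read-out at all, as the record still rests on a single point: the limit of < 10000 nM in this assay, at which 4 of the 4 values shown sit.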